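This account rests on a few compounds, and the source may have more. Where it says the series, first, only, none or still open, it means among the compounds named here.

Compound 2 `CC(C)(C)n1ncc(OCc2nnc(-c3ccco3)o2)c(Cl)c1=O` sits at the weak end of the two numbers shown. In a functional assay on the whole organism for inhibition, with Mythimna separata as the target, with a stated time of 5 days (on this read-out higher numbers stand for an effect only at larger amounts of compound and lower numbers for an effect already at smaller amounts), compound 2 gives > 299000 nM, which is a limit of the assay rather than a number. Compound 1 `CC(C)(C)n1ncc(OCc2nnc(-c3ccccc3Cl)o2)c(Cl)c1=O` carries 2-chlorophenyl where compound 2 carries furan-2-yl. In this assay compound 1 gives 61200 nM. Going by the values given here, the one measured step, an at least 4.8-fold higher number from compound 1 to compound 2 (0.68 log units; beyond the scatter), is bounded on one side only because of the limit of > 299000 nM in this assay, at which 1 of the 2 values shown sits. Compound 3 `CC(C)(C)n1ncc(OCc2nnc(-c3ccc(Cl)cc3Cl)o2)c(Cl)c1=O` differs from compound 2 by 2,4-dichlorophenyl in place of furan-2-yl on an aromatic carbon. Among the compounds with values here, this change runs in the opposite sense to the measured step, replacing the furan-2-yl with a chlorinated phenyl ring of the kind present in compound 1, so that step is the only guide. A reversal of at least that size is therefore expected, an at least 7.4-fold lower number from compound 2 to compound 3 (0.87 log units; beyond the scatter). Compound 3 is expected to give 40000 nM in this assay, with a range from 10000 nM to 200000 nM.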

Compound 3, half-maximal effective concentration: 27800 nM
For compound 3 the middle estimate is 1.4-fold (0.16 log units) above the measured one, within the range that was stated.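

In this assay, a chlorinated phenyl ring on this aromatic carbon now separates from furan-2-yl a second time, and by more, with an at least 10-fold lower number from compound 2 to compound 3 (1.03 log units; beyond the scatter). The figure for compound 2 is a limit and not a number, which leaves that step bounded on one side only: the limit of > 299000 nM in this assay, at which 1 of the 3 values shown sits. The phenyl ring itself also responds to substitution, as chloro in place of hydrogen, turning 2-chlorophenyl into 2,4-dichlorophenyl, gives a 2.2-fold lower number from compound 1 to compound 3 (0.34 log units; beyond the scatter), a modest step but beyond the scatter.

The compounds shown do not separate the contribution of the phenyl ring from that of its chlorines, since unsubstituted phenyl is absent from them. As far as these compounds go, whether methoxy, trifluoromethyl or methyl on the phenyl ring would follow chloro also remains open.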